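This account rests on a few compounds, and the source may have more. Where it says the series, first, only, none or still open, it means among the compounds named here.

Compound 3 `CC(NCc1ccccc1)c1nc([N+](=O)[O-])c(Sc2c(Cl)cncc2Cl)s1` gives the highest number of the three in an assay on isolated protein for inhibition of ubiquitin carboxyl-terminal hydrolase 7 (Homo sapiens), read by fluorescence, with stated times of 30 min and 3 h (a higher number here means a weaker inhibitor, a lower number a stronger inhibitor), at 26800 nM; compound 2 `CCCC(=O)OC(C)c1nc([N+](=O)[O-])c(Sc2c(Cl)cncc2Cl)s1` gives 4490 nM and compound 1 `CC(=O)c1nc([N+](=O)[O-])c(Sc2c(Cl)cncc2Cl)s1` gives 670 nM. Compound 4 `CC(O)c1nc([N+](=O)[O-])c(Sc2c(Cl)cncc2Cl)s1` carries hydroxy in place of benzylamino on a saturated chain carbon bound to an aromatic carbon and a saturated chain carbon. Among the compounds with values here, two measured steps bear on this change: a 6.0-fold higher number from compound 2 to compound 3 (0.78 log units; beyond the scatter), in which (propylcarbonyl)oxy gave way to benzylamino, and a 6.7-fold higher number from compound 1 to compound 2 (0.83 log units; beyond the scatter), in which acetyl became 1-((propylcarbonyl)oxy)ethyl. Putting hydroxy in place of benzylamino undoes the first of these, so a lower number in this assay is expected for compound 4, although a bare hydroxy at this place has not been measured in the series. Compound 4 is estimated at 3000 nM in this assay, within 800 nM to 12000 nM, an expected step of an 8.9-fold lower number from compound 3 to compound 4 (0.95 log units; beyond the scatter).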

Compound 4, half-maximal inhibitory concentration: 6950 nM
Compound 4: middle estimate off by 2.3-fold (0.36 log units), on the low side; low and high end bracket the measured number.
By their numbers in this assay, from the lowest: compound 1; then compounds 2 and 4 (each within the scatter of the next); then compound 3.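

Hydroxy in place of benzylamino gives a 3.9-fold lower number from compound 3 to compound 4 (0.59 log units; beyond the scatter) in this assay, so the weak result of compound 3 belongs to benzylamino rather than to this saturated chain carbon as such. Removing propylcarbonyl from the oxygen gives a 1.5-fold higher number from compound 2 to compound 4 (0.19 log units; within the scatter), so the free hydroxy and its ester are not separated here. The larger difference lies with acetyl on the aromatic carbon: a 10-fold higher number from compound 1 to compound 4 (1.02 log units; beyond the scatter). No available evidence accounts for these differences. Open, going by these compounds, is whether a plain amino group at the saturated chain carbon, or a longer ketone such as propanoyl in place of acetyl, would hold or change the number.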